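The source may hold more compounds than are shown below. What is called first, only, known or untested is meant among the compounds shown, and "the series" means these compounds.

Measured so far in a functional assay on MCF7 cells (Homo sapiens) for inhibition; on this read-out lower numbers stand for stronger inhibition and higher numbers for weaker inhibition: compound 1 `CC/C(=C(/c1ccc(/C=C/C(=O)O)cc1)c1cc2ccccc2[nH]1)c1cccc(C(F)(F)F)c1` gives 325 nM; compound 2 `CC/C(=C(/c1ccc(/C=C/C(=O)O)cc1)c1cc2ccccc2[nH]1)c1ccc(C#N)cc1Cl` gives 49 nM.

Compound 1 stands at the highest number of the two. Compound 3 `CC/C(=C(/c1ccc(/C=C/C(=O)O)cc1)c1cc2ccccc2[nH]1)c1ccc(C(F)(F)F)cc1Cl` differs from compound 1 by 2-chloro-4-(trifluoromethyl)phenyl in place of 3-(trifluoromethyl)phenyl on a double-bonded chain carbon bound to a double-bonded chain carbon and a saturated chain carbon. For the measured compounds named here, the only step bearing on this is a 6.6-fold lower number from compound 1 to compound 2 (0.82 log units; beyond the scatter), which likewise replaces the 3-(trifluoromethyl)phenyl with a ring carrying a chlorine, though there the second group is a nitrile rather than a trifluoromethyl. Because that step was a 6.6-fold lower number from compound 1 to compound 2 (0.82 log units; beyond the scatter), a gain in the same direction but somewhat smaller is expected for compound 3, a 2.7-fold lower number from compound 1 to compound 3 (0.43 log units; beyond the scatter). Compound 3 is estimated at 120 nM in this assay, with a range from 40 nM to 400 nM.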

Compound 3, half-maximal inhibitory concentration: 27 nM
Compound 3: middle estimate off by 4.4-fold (0.65 log units), on the high side; the whole stated range lies above it.
By their numbers in this assay, from the lowest: compounds 3 and 2 (each within the scatter of the next); then compound 1.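

In this assay the change from 3-(trifluoromethyl)phenyl to 2-chloro-4-(trifluoromethyl)phenyl gives a 12-fold lower number from compound 1 to compound 3 (1.08 log units; beyond the scatter) and shows that a large step at this position does not need the nitrile of compound 2. Trifluoromethyl in place of cyano on an aromatic carbon gives a 1.8-fold lower number from compound 2 to compound 3 (0.26 log units; within the scatter) and so does not separate these two groups on this read-out. No evidence on the cause of either step is at hand.

Open, as far as these compounds go, is how much of the step from 3-(trifluoromethyl)phenyl belongs to the added chlorine and how much to the changed location of the trifluoromethyl. Also open, from the compounds shown here alone, is whether bromine or methoxy could stand in place of that chlorine.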